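The source may report more compounds than this note shows. Statements on the series, on what has been measured and on what is new or still open speak of the compounds shown alone.

Measured in a functional assay on K562 cells (Homo sapiens) for inhibition, read by trypan blue exclusion, with a stated time of 72 h; a higher number here means a weaker inhibitor, a lower number a stronger inhibitor:

compound 1 `Cn1c(=O)c(S(=O)(=O)c2ccc(F)cc2)cc2cnc(Nc3ccc4occc4c3)nc21` gives 5000 nM
compound 2 `Cn1c(=O)c(S(=O)(=O)c2ccc(F)cc2)cc2cnc(Nc3ccc4[nH]ncc4c3)nc21` gives 10000 nM
compound 3 `Cn1c(=O)c(S(=O)(=O)c2ccc(Cl)cc2)cc2cnc(Nc3cnc4[nH]ccc4c3)nc21` gives 5000 nM

Compound 3 at 5000 nM reads the same as compound 1 at 5000 nM. Compound 2 at 10000 nM lies within the scatter of both, so the three values cannot be ranked.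

The next compound is compound 4 `Cn1c(=O)c(S(=O)(=O)c2ccc(F)cc2)cc2cnc(Nc3cnc4[nH]ccc4c3)nc21`, which has fluoro in place of chloro on an aromatic carbon, para to a large group, so that 4-chlorophenyl becomes 4-fluorophenyl: fluoro in place of chloro on an aromatic carbon.

For the measured compounds named here, no measured pair isolates this exchange. Going by the values given here, the only measured step is a 2.0-fold higher number from compound 1 to compound 2 (0.30 log units; within the scatter). It concerns the group on the nitrogen on an aromatic ring, not the halogen, and it bears on the present change only indirectly. Compound 1 and compound 2 already carry the (4-fluorophenyl)sulfonyl group that compound 4 will have, and their values stay within the scatter of the value of compound 3. With nothing in the series pointing to a larger effect, no step beyond the scatter is expected in this assay.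

The expected step is no change at the digits printed from compound 3 to compound 4 (within the scatter).

For compound 4 the estimated value is 5000 nM, with an expected range from 2500 nM to 10000 nM.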

Compound 4, half-maximal inhibitory concentration: 750 nM
For compound 4 the middle estimate is 6.7-fold (0.82 log units) above the measured one; the measured number lies below the stated range.
By their numbers in this assay, from the lowest: compound 4; then compounds 1, 3 and 2 (each within the scatter of the next).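

Working notes: in this assay the halogen on the phenylsulfonyl group is the first single exchange in the series to move the read-out, with a 6.7-fold lower number from compound 3 to compound 4 (0.82 log units; beyond the scatter) for fluoro in place of chloro on an aromatic carbon, para to a large group. With the (4-fluorophenyl)sulfonyl group held constant, the group on the nitrogen also matters: the change from 1-benzofuran-5-yl gives a 6.7-fold lower number from compound 1 to compound 4 (0.82 log units; beyond the scatter) and the change from 1H-indazol-5-yl gives a 13-fold lower number from compound 2 to compound 4 (1.12 log units; beyond the scatter), although those two groups could not be separated from each other. For the compounds shown here, compound 4 is therefore the most potent of the four, the only one whose steps to all the others lie beyond the scatter.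

No evidence is available on why the exchange of chloro for fluoro or the change of the group on the nitrogen shifts the read-out.

As far as these compounds go, the halogen exchange rests on a single pair, so its size with 1-benzofuran-5-yl or 1H-indazol-5-yl on the nitrogen remains open. Also open, from the compounds shown here alone, is how a methoxy group, a trifluoromethyl group or a plain hydrogen would read at the same aromatic carbon.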